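Chloro for hydrogen on the fused core: benzyl chloride series

A few compounds are considered here, and "the series" means these few. Any claim that something is new, unique, unknown or untested is made for them only; others in the source may bear on it.

Measured compounds:
compound 1 `ClCc1ccc(Cn2cnc3c(Cl)ncnc32)cc1` — 15100 nM
compound 2 `ClCc1cccc(Cn2cnc3ncnc(Cl)c32)c1` — 14800 nM

Two compounds have been run in a functional assay on OVCAR-8 cells (Homo sapiens) for cytotoxicity, read by sulforhodamine B assay, with a stated time of 48 h; a lower number here means a stronger inhibitor of growth, a higher number a weaker inhibitor of growth. In this assay, among the measured compounds shown here, compound 1 gives 15100 nM and compound 2 gives 14800 nM; the two numbers sit within the scatter of each other, so neither stands apart, and with only two compounds no step between measured compounds can be read.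

Compound 3 `ClCc1ccc(Cn2cnc3c(Cl)nc(Cl)nc32)cc1` has not been measured. It differs from compound 1 by chloro in place of hydrogen on an aromatic carbon, a chloro in place of hydrogen on an aromatic carbon. For the measured compounds named here, no measured pair shows what such a change does, so nothing in the data points to a direction. Compound 3 is therefore estimated at 10000 nM, with a range from 3000 nM to 40000 nM. The expected step of a 1.5-fold lower number from compound 1 to compound 3 (0.18 log units; within the scatter) is placed within the scatter, with the range left wide to allow for either direction.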

Compound 3, concentration for total growth inhibition: 38000 nM
Compound 3: the middle estimate sits 3.8-fold (0.58 log units) below what was measured, and the stated range covers the measured number.
By their numbers in this assay, from the lowest: compounds 2 and 1 (each within the scatter of the next); then compound 3.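

In this assay chloro in place of hydrogen on the aromatic carbon between two ring nitrogen atoms gives a 2.5-fold higher number from compound 1 to compound 3 (0.40 log units; beyond the scatter) and so a weaker inhibitor of growth. Among the compounds shown here, this is the first readable step: this position of the shared core is sensitive to substitution, and this change costs modest activity. The finding rests on a single pair, and no measurement at hand gives a reason for the step.

Going by these compounds, whether the loss is particular to chloro remains open, as an amine or a methoxy group on the same carbon could move the number in either direction. Also open, on these data alone, is whether the same chloro change on compound 2 would give a step of similar size and direction.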